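The source may hold more compounds than are shown below. What is called first, only, known or untested is meant among the compounds shown, and "the series" means these compounds.

In a functional assay on CFPAC-1 cells (Homo sapiens) for antiproliferative activity, read by MTT assay, with a stated time of 72 h (a higher number here means a weaker inhibitor, a lower number a stronger inhibitor), compound 1 `COc1ccccc1-c1cn(C[C@H](O)[C@H]2OC(=O)C(OCc3ccccc3)=C2OCc2ccccc2)nn1` gives only a limit, > 100000 nM, and not a true number. For the measured compounds named here, compound 2 `COc1ccc(-c2cn(C[C@H](O)[C@H]3OC(=O)C(OCc4ccccc4)=C3OCc3ccccc3)nn2)cc1` gives 26000 nM, the only true number so far. Compound 3 `O=C1O[C@H]([C@@H](O)Cn2cc(CCO)nn2)C(OCc2ccccc2)=C1OCc1ccccc1` has not yet been measured. It carries 2-hydroxyethyl in place of 4-methoxyphenyl on an aromatic carbon of a five-membered aromatic ring with 3 nitrogen: 2-hydroxyethyl in place of 4-methoxyphenyl on an aromatic carbon. Going by the values given here, only one measured step bears on this change. That step, an at least 3.8-fold lower number from compound 1 to compound 2 (0.58 log units; beyond the scatter), lies beyond the scatter and shows that a swap on this kind of carbon can shift the result. It exchanged one methoxyphenyl group for another, however, so it is only a loose guide when the ring is lost altogether. A modest rise in the number, meaning a weaker inhibitor, is therefore expected in this assay. The expected change is a 1.9-fold higher number from compound 2 to compound 3 (0.28 log units; within the scatter). For compound 3 the estimate is 50000 nM, with an expected range of 18000 nM to 150000 nM.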

Compound 3, half-maximal inhibitory concentration: > 100000 nM
Compound 3 ended at the assay's limit; the forecaster's own chance of this, stated with the estimate: 40%; middle value at least 2.0-fold (0.30 log units) away from the limit.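

In this assay, the earlier step only swapped one methoxyphenyl group for another, whereas this change removes the six-membered aromatic ring from this aromatic carbon and puts 2-hydroxyethyl there. The result is an at least 3.8-fold higher number from compound 2 to compound 3 (0.58 log units; beyond the scatter), so a group with no ring at this carbon gives a weaker result than 4-methoxyphenyl. Compound 3 gives > 100000 nM, which is a limit of the assay and not a true number, and the step from compound 1 to compound 3 cannot be read because both compounds end at a limit: the limit of > 100000 nM in this assay, at which 2 of the 3 values shown sit.

The compounds shown do not separate the loss of the ring from the gain of the hydroxyl group, which a plain ethyl or a 2-phenylethyl group on this carbon could help to do. From the compounds shown here alone, it also stays open how other groups without a ring, such as an amine, a carboxylic acid or a longer chain, would behave here.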